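This account rests on a few compounds, and the source may have more. Where it says the series, first, only, none or still open, it means among the compounds named here.

Measured in a functional assay on SGC-7901 cells (Homo sapiens) for antiproliferative activity, read by MTT assay, with a stated time of 72 h; on this read-out lower numbers stand for stronger inhibition and higher numbers for weaker inhibition:
- compound 1 `C=C1C(=O)[C@@]23C(=O)OC[C@]4([C@@H](OC(C)=O)CCC(C)(C)[C@H]4C=O)[C@@H]2CC[C@@H]1[C@H]3O` gives 49800 nM
- compound 2 `C=C1C(=O)[C@@]23C(=O)OC[C@]4(C(=O)CCC(C)(C)[C@H]4C=O)[C@@H]2CC[C@@H]1[C@H]3OC(=O)CCC(=O)Oc1ccc(-c2cc(=S)ss2)cc1` gives 4240 nM
- compound 3 `C=C1C(=O)[C@@]23C(=O)OC[C@]4(C(=O)CCC(C)(C)[C@H]4C=O)[C@@H]2CC[C@@H]1[C@H]3OC(=O)CCCC(=O)Oc1ccc(-c2cc(=S)ss2)cc1` gives 4360 nM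

Compound 1 holds the highest of the three numbers and is the weakest of them, with compound 2 and compound 3 both lower by more than the scatter. Compound 2 and compound 3 lie within the scatter of each other.

Next in line is compound 4 `C=C1C(=O)[C@@]23C(=O)OC[C@]4([C@@H](OC(C)=O)CCC(C)(C)[C@H]4C=O)[C@@H]2CC[C@@H]1[C@H]3OC(=O)CCCCC1CCSS1`, which keeps the core of compound 1 and differs from it in one place: a group of 11 heavy atoms (8 carbon, 1 oxygen, 2 sulfur; one five-membered non-aromatic ring with 2 hetero atoms) in place of a hydrogen atom, on an oxygen on a saturated carbon. Going by the values given here, no measured pair isolates a change of this kind. Compound 2 at 4240 nM and compound 3 at 4360 nM also carry a sulfur-containing group on an oxygen on a saturated carbon, but both differ from compound 1 in a second place as well, so they indicate a direction only and not a size.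

In this assay a moderate fall in the number, beyond the scatter, is therefore expected, though probably a smaller one than compound 2 and compound 3 show. The expected change is a 4.2-fold lower number from compound 1 to compound 4 (0.62 log units; beyond the scatter). The estimate for compound 4 is 12000 nM, with an expected range from 3500 nM to 35000 nM.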

Compound 4, half-maximal inhibitory concentration: 10000 nM
For compound 4 the middle estimate is 1.2-fold (0.08 log units) above the measured one; measured number inside the range.
By their numbers in this assay, from the lowest: compounds 2 and 3 (each within the scatter of the next); then compound 4; then compound 1.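

In this assay the change at this oxygen now has a size of its own: the group of 11 heavy atoms in place of a hydrogen atom gives a 5.0-fold lower number from compound 1 to compound 4 (0.70 log units; beyond the scatter) with the rest of the core of compound 1 unchanged. The hydrogen on this oxygen is therefore not required for activity in this read-out, and the position accepts a group carrying a five-membered non-aromatic ring with 2 hetero atoms. Compound 2 and compound 3 gave only a direction. Each of them also differs from compound 1 in a second place. Nothing available bears on the cause of this step.

From the compounds shown here alone, whether the lower number depends on the sulfur-containing ring or on the chain that carries it remains open; a plain alkyl chain without sulfur at this oxygen, or the same chain ending in a carboxylic acid or an amine, would separate the two. Also open, going by these compounds, is how much of the lower numbers of compound 2 and compound 3 belongs to the group on this oxygen and how much to their second difference from compound 1.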